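Swapping the aryl substituent on the shared core for permeability

A few compounds are considered here, and "the series" means these few. Any claim that something is new, unique, unknown or untested is made for them only; others in the source may bear on it.

Of the compounds shown here, three of a shared core have been measured in an ADME assay for permeability, using PAMPA, with a stated time of 30 min, at pH 7.4; on this read-out higher numbers stand for higher permeability and lower numbers for lower permeability. Compound 1 `Fc1ccc(Cc2ccc3c(NCCCNCc4ccco4)ccnc3c2)c(Cl)c1` gives 23 10^-6 cm/s. Compound 2 `COc1cccc(Oc2ccc3c(NCCCNCc4cccc(OC)c4O)ccnc3c2)c1` gives 317 10^-6 cm/s. Compound 3 `COc1ccc(-c2ccc3c(NCCCNCc4ccco4)ccnc3c2)cc1` gives 237 10^-6 cm/s, a value that lies within the usual scatter of the value of compound 2 and well beyond it relative to compound 1.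

Compound 4 `COc1cccc(Oc2ccc3c(NCCCNCc4ccco4)ccnc3c2)c1` has not yet been measured. It differs from compound 3 in one place: 3-methoxyphenoxy in place of 4-methoxyphenyl on an aromatic carbon.

Among the compounds with values here, one measured step bears on this position. The step of a 10-fold higher number from compound 1 to compound 3 (1.01 log units; beyond the scatter) shows that what sits on this aromatic carbon can move the number strongly. Like compound 4, compound 2 carries a 3-methoxyphenoxy group, though on a different side chain; in this assay compound 2 gives 317 10^-6 cm/s, a value within the scatter of compound 3. Within the data shown here, no measured step isolates the swap from 4-methoxyphenyl to 3-methoxyphenoxy itself.

For compound 4 the expected step is a 1.1-fold higher number from compound 3 to compound 4 (0.06 log units; within the scatter), which is not beyond the scatter. The estimate for compound 4 in this assay is therefore 270 10^-6 cm/s, with a range from 120 10^-6 cm/s to 600 10^-6 cm/s.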

Compound 4, apparent permeability: 317 10^-6 cm/s
Compound 4: middle estimate off by 1.2-fold (0.07 log units), on the low side, within the range that was stated.
By their numbers in this assay, from the lowest: compound 1; then compounds 3, 2 and 4 (each within the scatter of the next).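

In this assay the step of a 1.3-fold higher number from compound 3 to compound 4 (0.13 log units; within the scatter) leaves 3-methoxyphenoxy and 4-methoxyphenyl on this aromatic carbon indistinguishable, although 3-methoxyphenoxy carries one more hydrogen-bond acceptor by count. The side chain gives a similar picture, with no change at the digits printed from compound 2 to compound 4 (within the scatter) when furan-2-yl takes the place of 2-hydroxy-3-methoxyphenyl while 3-methoxyphenoxy stays on the core. Of the three groups seen on this carbon, only 2-chloro-4-fluorobenzyl stands apart, as the step of a 14-fold higher number from compound 1 to compound 4 (1.14 log units; beyond the scatter) shows alongside the earlier step of a 10-fold higher number from compound 1 to compound 3 (1.01 log units; beyond the scatter).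

No measurement shown gives a reason for these numbers. On these data alone, it remains open whether an amine or a carboxylic acid on this aromatic carbon would stay level with compound 3 and compound 4 or fall toward compound 1.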